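This account rests on a few compounds, and the source may have more. Where it says the series, first, only, none or still open, it means among the compounds named here.

Working notes on a urea series built on a shared core. Compound 1 `CN(C)c1ccc(NC(=O)Nc2cccc(CNc3nccnc3Cl)c2)cc1` stands at the floor of what a functional assay on HepG2 cells (Homo sapiens) for antiproliferative activity, read by MTT assay, with a stated time of 48 h (a higher number here means a weaker inhibitor, a lower number a stronger inhibitor), can report: compound 1 gives > 40000 nM, a limit of the assay and not a number. Compound 3 `O=C(Nc1cccc(CNc2nccnc2Cl)c1)NC1CCCCC1` also rests at the limit, with > 40000 nM. Compound 2 `Cc1cccc(NC(=O)Nc2cccc(CNc3nccnc3Cl)c2)c1` alone gives a number, 11200 nM. Thus two of three values sit at the limit of > 40000 nM in this assay, at which 2 of the 3 values shown sit. The change to compound 4 `O=C(Nc1cccc(CNc2nccnc2Cl)c1)Nc1ccc(Cl)cc1Br` is 2-bromo-4-chlorophenyl in place of 4-(dimethylamino)phenyl on an amide-type nitrogen. The measured step that bears on it is an at least 3.5-fold lower number from compound 1 to compound 2 (0.55 log units; beyond the scatter), where another substituted phenyl replaced 4-(dimethylamino)phenyl; an at least 3.5-fold higher number from compound 2 to compound 3 (0.55 log units; beyond the scatter) runs the other way, while a step that the two limits leave unreadable from compound 1 to compound 3. Since compound 4 likewise carries a substituted phenyl, a step of similar size and direction is expected, an at least 2.6-fold lower number from compound 1 to compound 4 (0.42 log units; beyond the scatter). Compound 4 is therefore estimated at 15000 nM, between 5000 nM and 45000 nM.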

Compound 4, half-maximal inhibitory concentration: 6720 nM
Compound 4: middle estimate off by 2.2-fold (0.35 log units), on the high side, and the stated range covers the measured number.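

In this assay, 2-bromo-4-chlorophenyl on the amide-type nitrogen gives a second substituted phenyl with a measured number, with an at least 5.9-fold lower number from compound 1 to compound 4 (0.77 log units; beyond the scatter) and an at least 5.9-fold lower number from compound 3 to compound 4 (0.77 log units; beyond the scatter). Against 3-methylphenyl there is only a 1.7-fold lower number from compound 2 to compound 4 (0.22 log units; within the scatter), so compound 2 and compound 4 stand level, while compound 1 goes against any rule that a substituted phenyl alone is enough. The two larger steps are bounds and not sizes: the limit of > 40000 nM in this assay, at which 2 of the 4 values shown sit.

From the compounds shown here alone, whether the bromine, the chlorine or both matter in compound 4 stays open. Also open, going by these compounds, is how a carboxylic acid or a primary amine on the phenyl would read here.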